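Hydrogen in Place of Methoxycarbonyl: A Step at a Limit

The source may report more compounds than this note shows. Statements on the series, on what has been measured and on what is new or still open speak of the compounds shown alone.

Compound 1 `CN(C(=O)CN1CCN(c2nc(=O)c3cc(C(F)(F)F)cc([N+](=O)[O-])c3s2)CC1)c1ccccc1`: > 10000 nM (a limit)
Compound 2 `COC(=O)C1CN(c2nc(=O)c3cc(C(F)(F)F)cc([N+](=O)[O-])c3s2)CCC12OC[C@H](C)O2`: > 10000 nM (a limit)
Compound 3 `O=c1nc(N2CCC(F)(F)CC2)sc2c([N+](=O)[O-])cc(C(F)(F)F)cc12`: > 10000 nM (a limit)

All three compounds were tested in an ADME assay on HepG2 cells (Homo sapiens) for cytotoxicity, read by MTT assay, with a stated time of 24 h; on this read-out lower numbers stand for higher toxicity in this test and higher numbers for lower toxicity in this test. Compound 2 gives > 10000 nM there, and this is a limit of the test, not a number. The other two compounds give the same kind of result: the limit of > 10000 nM in this assay, at which 3 of the 3 values shown sit. Compound 2 therefore has no exact place in an order of the three, since none of them has an exact value.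

Compound 4 `C[C@H]1COC2(CCN(c3nc(=O)c4cc(C(F)(F)F)cc([N+](=O)[O-])c4s3)CC2)O1` differs from compound 2 at one place: hydrogen in place of methoxycarbonyl on a saturated ring carbon. In plain words, hydrogen stands in place of methoxycarbonyl on a saturated ring carbon, and the rest of the structure stays the same.

Going by the values given here, no measured pair shows this change on its own, so its size cannot be read directly. Still, the three measured compounds carry different groups on the shared core, and all of them end at the limit: the limit of > 10000 nM in this assay, at which 3 of the 3 values shown sit. The expectation is no step beyond the usual scatter, and another limit of the test is the likeliest expected outcome: a step that the limit leaves unreadable from compound 2 to compound 4. The estimate for compound 4 is 15000 nM, with an expected range from 5000 nM to 40000 nM.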

Compound 4, half-maximal cytotoxic concentration: > 10000 nM
Compound 4: a limit, no number (the forecaster's own chance of this, stated with the estimate: 85%); the middle value lies beyond the limit too.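

In this assay compound 4 gives > 10000 nM, which is a limit of the test and not a number. Compound 2 also sits at a limit, so no size can be read for the step between compound 2 and compound 4. The compounds shown leave open at what concentration each would become toxic to these cells, and whether hydrogen in place of methoxycarbonyl changes that concentration.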